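Swapping Phenyl for Benzyl on a Ring Nitrogen

A few compounds are considered here, and "the series" means these few. Any claim that something is new, unique, unknown or untested is made for them only; others in the source may bear on it.

Measured so far:
compound 1 `CN(C)/C=C/N1CCN(CC(=O)Nc2ccc(-c3nc(-c4ccccc4)c(-c4ccccc4)n3C)cc2)CC1` gives 1.9%
compound 2 `Cn1c(-c2ccc(NC(=O)CN3CCN(c4ccccc4)CC3)cc2)nc(-c2ccccc2)c1-c1ccccc1` gives 21.3%

For the measured compounds named here, in a functional assay on MCF7 cells (Homo sapiens) for cytotoxicity, read by MTT assay, with a stated time of 24 h, tested at 1.6 ug/mL (on this read-out higher numbers stand for a stronger effect at the one concentration tested and lower numbers for a weaker effect), compound 2 stands highest of the two numbers, and the only measured step, a number 19.4 percentage points higher from compound 1 to compound 2 (beyond the scatter), is the one that separates compound 2 from compound 1. Compound 3 `Cn1c(-c2ccc(NC(=O)CN3CCN(Cc4ccccc4)CC3)cc2)nc(-c2ccccc2)c1-c1ccccc1` differs from compound 2 in one place: benzyl in place of phenyl on an amine nitrogen in a ring. That measured step exchanged a quite different group on the same ring nitrogen, so it does not show how a benzyl compares with a phenyl there, and it offers no direct guide. With nothing else to go on, the expectation is that the change leaves the read-out roughly where compound 2 sits, so the step of a number 1.3 percentage points lower from compound 2 to compound 3 (within the scatter) is expected to stay within the scatter. Compound 3 is therefore estimated at 20%, within a range from 5% to 40%.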

Compound 3, a percentage reported as activity, at one concentration (the size of the read-out at that concentration, not a potency): 13.3%
For compound 3 the middle estimate is 6.7 percentage points above the measured one, and the stated range covers the measured number.
By their numbers in this assay, from the lowest: compound 1; then compounds 3 and 2 (each within the scatter of the next).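

In this assay, replacing phenyl with benzyl on this amine nitrogen in a ring brings 7 heavy atoms in place of 6 and keeps one six-membered aromatic ring, and it gives a number 8 percentage points lower from compound 2 to compound 3 (within the scatter), so this read-out does not separate the two groups. Benzyl, like phenyl, does stand apart from 2-(dimethylamino)ethenyl at this position, with a number 11.4 percentage points higher from compound 1 to compound 3 (beyond the scatter) as the new comparison. No measurement is available that would explain these numbers.

Still open, going by these compounds, is how the read-out responds to a longer chain on this nitrogen, such as phenethyl, or to a ring that contains nitrogen, such as pyridyl. These numbers describe only the size of the effect at the one concentration tested, so they leave open whether the compounds would keep the same stronger or weaker effect at any other concentration.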